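Ethyl for hydrogen on the imine carbon of compound 3

This account rests on a few compounds, and the source may have more. Where it says the series, first, only, none or still open, it means among the compounds named here.

Compound 1 `CC/N=C(\S)NCCCCCn1nc(-c2ccccc2)ccc1=O`: 51.8 mg/kg
Compound 2 `C/N=C(/NC#N)NCCCCCCn1nc(-c2ccccc2)ccc1=O`: > 100 mg/kg (a limit of the assay)
Compound 3 `C/N=C(/NC#N)NCCCCCn1nc(-c2ccccc2)ccc1=O`: 100 mg/kg

In a functional assay on the whole organism (stomach) with Rattus norvegicus as the target (on this read-out lower numbers stand for an effect already at smaller amounts and higher numbers for an effect only at larger amounts of compound), compound 3 gives 100 mg/kg, the higher of the two numbers, and its nearest neighbour compound 1 lies a 1.9-fold higher number from compound 1 to compound 3 (0.29 log units; within the scatter). For compound 2 only a limit is recorded (the limit of > 100 mg/kg in this assay, at which 1 of the 3 values shown sits). Compound 4 `CCC/N=C(/NC#N)NCCCCCn1nc(-c2ccccc2)ccc1=O` carries ethyl in place of hydrogen on a saturated chain carbon bound to a double-bonded nitrogen. Among the measured compounds shown here, no measured step touches this position; the step of a 1.9-fold higher number from compound 1 to compound 3 (0.29 log units; within the scatter) changes the chain-end group, and a number no higher from compound 2 to compound 3 (the limit leaves the size open) shortens the chain. Nothing recorded therefore points to a change beyond the scatter, and compound 4 is estimated at 95 mg/kg, between 40 mg/kg and 220 mg/kg, meaning an expected step of a 1.1-fold lower number from compound 3 to compound 4 (0.02 log units; within the scatter).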

Compound 4, dose for half-maximal effect: > 100 mg/kg
Compound 4 was reported as a limit; the forecaster's own chance of this, stated with the estimate: 35%; at least 1.0-fold (0.02 log units) between middle value and limit.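

In this assay ethyl in place of hydrogen on this saturated chain carbon bound to a double-bonded nitrogen gives only a limit of the assay for compound 4, so the record shows a number no lower from compound 3 to compound 4 (the limit leaves the size open) and no gain from this change. The record also gives an at least 1.9-fold higher number from compound 1 to compound 4 (0.28 log units; that floor lies within the scatter) and thus establishes no difference beyond the scatter, while the step that joins compound 2 and compound 4 cannot be read. The upper end of the read-out now holds two compounds: the limit of > 100 mg/kg in this assay, at which 2 of the 4 values shown sit.

Going by these compounds, how far compound 4 lies past its limit stays open. Also open, on these data alone, is whether methyl, a longer chain such as butyl, or a ring such as cyclopropyl in this place would give a number that can be read.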